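This account rests on a few compounds, and the source may have more. Where it says the series, first, only, none or still open, it means among the compounds named here.

Measured so far:
compound 1 `CS(=O)(=O)Oc1c(C(=O)NCc2ccc(F)cc2)nc(Br)c2cccnc12` — > 20000 nM
compound 2 `O=C(NCc1ccc(F)cc1)c1nc(Br)c2cccnc2c1NCCCNc1c(C(=O)NCc2ccc(F)cc2)nc(Br)c2cccnc12` — > 20000 nM

In a functional assay on HCT-116 cells (Homo sapiens) for cytotoxicity, read by MTT assay, with a stated time of 72 h (a lower number here means a stronger inhibitor, a higher number a weaker inhibitor), compound 1 gives > 20000 nM, a limit of the assay rather than a number. Compound 2 gives > 20000 nM, again only a limit. Among the compounds with values here, the sole evidence is the limit of > 20000 nM in this assay, at which 2 of the 2 values shown sit, so compound 1 cannot be placed against compound 2. Compound 3 `CNCCCNc1c(C(=O)NCc2ccc(F)cc2)nc(Br)c2cccnc12` awaits measurement; it differs from compound 1 by (3-(methylamino)propyl)amino in place of (methylsulfonyl)oxy on an aromatic carbon. Within the data shown here, with no measured step available, the change from compound 1 to compound 3 in this assay is expected to be modest, most likely none beyond the scatter, with a move toward stronger inhibition possible. Compound 3 is estimated at 12000 nM, within 3000 nM to 40000 nM, an expected step of an at least 1.6-fold lower number from compound 1 to compound 3 (0.22 log units; that floor lies within the scatter).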

Compound 3, half-maximal inhibitory concentration: 9000 nM
Beside the measured number, compound 3's estimate is 1.3-fold (0.12 log units) above it, and the stated range covers the measured number.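

In this assay, the aromatic carbon para to a bromo group responds to substitution: (3-(methylamino)propyl)amino in place of (methylsulfonyl)oxy gives an at least 2.2-fold lower number from compound 1 to compound 3 (0.34 log units; beyond the scatter). Of the compounds shown, only compound 3 has a measured number, 9000 nM, rather than a limit. The full size of the step stays unknown, and only a floor can be read: the limit of > 20000 nM in this assay, at which 2 of the 3 values shown sit.

From the compounds shown here alone, whether a primary amine, a dimethylamino end or a longer chain at this position would shift the number further remains open. Going by these compounds, the contribution of the bromo group to this activity also remains open.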